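Ester series in the hot plate test: compound 4

A few compounds are considered here, and "the series" means these few. Any claim that something is new, unique, unknown or untested is made for them only; others in the source may bear on it.

Measured compounds:
compound 1 `Cc1ccc(C(=O)OC2CCN(C)CC2)cc1` — 18.2 mg/kg
compound 2 `CN1CCC(OC(=O)c2ccc(C(C)(C)C)cc2)CC1` — 23.3 mg/kg
compound 3 `COc1ccccc1C(=O)OC1CCN(C)CC1` — 10.6 mg/kg

In a functional assay on the whole organism with Mus musculus as the target, in the hot plate test (a higher number here means that more compound is needed for the effect, a lower number that less compound is needed), compound 3 gives 10.6 mg/kg, the lowest of the three numbers; its gap to compound 1 is within the scatter, its gap to compound 2 beyond it. Compound 4 `COc1cccc(C(=O)OC2CCN(C)CC2)c1OC` differs from compound 3 by methoxy in place of hydrogen on an aromatic carbon. For the measured compounds named here, the only step measured so far, a 1.3-fold higher number from compound 1 to compound 2 (0.11 log units; within the scatter), concerns an alkyl change and does not bear on a methoxy entering; no measured step touches this change. No step beyond the scatter is therefore expected in this assay. The estimate means an expected step of a 1.1-fold higher number from compound 3 to compound 4 (0.05 log units; within the scatter). Compound 4 is expected to give about 12 mg/kg, between 6 mg/kg and 25 mg/kg.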

Compound 4, dose for half-maximal effect: 8.9 mg/kg
For compound 4 the middle estimate is 1.3-fold (0.13 log units) above the measured one, within the range that was stated.
By their numbers in this assay, from the lowest: compounds 4, 3, 1 and 2 (each within the scatter of the next, the first and the last beyond it).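

In this assay methoxy in place of hydrogen, ortho to a methoxy group and meta to a large group, gives a 1.2-fold lower number from compound 3 to compound 4 (0.08 log units; within the scatter) and stays within the scatter. This aromatic carbon therefore accepts a further methoxy with no clear change in the number, which the alkyl step between compounds 1 and 2 could not show. Nothing available explains this result. As far as these compounds go, whether an amine, a carboxylic acid or a longer chain at this carbon would also leave the number in place remains open. So does the effect of methoxy here without the neighbouring methoxy of compound 3.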